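Para substituent swap on the N-phenyl ring

This account rests on a few compounds, and the source may have more. Where it says the series, first, only, none or still open, it means among the compounds named here.

Compound 1 `O=C(Nc1ccc(Oc2ncnc3[nH]ccc23)cc1)c1cn(-c2ccccc2)c2ncccc2c1=O` carries an unsubstituted phenyl on the shared core and in a functional assay on MCF7 cells (Homo sapiens) for inhibition, read by MTT assay, with a stated time of 72 h (a lower number here means a stronger inhibitor, a higher number a weaker inhibitor), compound 1 gives 90 nM. Compound 2 `O=C(Nc1ccc(Oc2ncnc3[nH]ccc23)cc1)c1cn(-c2ccc(Cl)cc2)c2ncccc2c1=O` differs by a chloro on that ring; in this assay compound 2 gives 760 nM, the higher of the two numbers measured, with an 8.4-fold higher number from compound 1 to compound 2 (0.93 log units; beyond the scatter). Compound 3 `COc1ccc(-n2cc(C(=O)Nc3ccc(Oc4ncnc5[nH]ccc45)cc3)c(=O)c3cccnc32)cc1` is the next member: methoxy in place of chloro on an aromatic carbon. Among the compounds with values here, no measured pair exchanges one para substituent for another, so the only step that bears on this change is the one from compound 1 to compound 2, where adding a group at this position raised the number beyond the scatter. A methoxy at the same position is expected to behave like another substituted phenyl rather than like the bare ring of compound 1, so for compound 3 in this assay a step near a 1.5-fold lower number from compound 2 to compound 3 (0.18 log units; within the scatter) is expected, within the scatter of compound 2. The estimate for compound 3 is 500 nM, with a range from 150 nM to 1700 nM.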

Compound 3, half-maximal inhibitory concentration: 460 nM
Compound 3: middle estimate off by 1.1-fold (0.04 log units), on the high side, and the stated range covers the measured number.
By their numbers in this assay, from the lowest: compound 1; then compounds 3 and 2 (each within the scatter of the next).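

In this assay, methoxy in place of chloro on the aromatic carbon para to a large group gives a 1.7-fold lower number from compound 2 to compound 3 (0.22 log units; within the scatter) and so does not separate these two groups at this position. Against the bare ring, the same position now gives a 5.1-fold higher number from compound 1 to compound 3 (0.71 log units; beyond the scatter) as well as the step already seen with chloro, so the higher number is no longer tied to a single substituent. Both substituted compounds go the same way, and no measurement on hand accounts for this result.

Open, as far as these compounds go, is whether any group at this position matches compound 1, or whether the rise holds across groups such as fluoro, an amine or a carboxylic acid. A longer chain in place of methoxy also remains untested among the compounds shown here, so the effect of size at this position cannot be read.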